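This account rests on a few compounds, and the source may have more. Where it says the series, first, only, none or still open, it means among the compounds named here.

Compound 1 `Cc1cccc(-c2n[nH]cc2N2CCCNCC2)c1` reaches no number in an assay on isolated protein for binding affinity to 5-hydroxytryptamine receptor 1E (Homo sapiens); a lower number here means a stronger inhibitor, a higher number a weaker inhibitor; it gives only a limit of the assay, > 10000 nM. Compound 2 `Cc1ccc(-c2n[nH]cc2N2CCCNCC2)cc1` likewise gives only a limit in this assay, > 10000 nM. Both stand at the limit of > 10000 nM in this assay, at which 2 of the 2 values shown sit. Compound 3 `Fc1cccc(-c2n[nH]cc2N2CCCNCC2)c1` differs from compound 1 by fluoro in place of methyl on an aromatic carbon. Within the data shown here, no step between measured compounds is available, so in this assay no change beyond the scatter is expected in either direction. Compound 3 is therefore expected to give about 10000 nM, with a range from 3000 nM to 30000 nM. The expected step of a number no higher from compound 1 to compound 3 (the limit leaves the size open) is thus none beyond the scatter.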

Compound 3, inhibition constant: > 10000 nM
Compound 3: a limit, no number; the forecaster's own chance of this, stated with the estimate: 80%; the middle value lies on the limit itself.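

In this assay, among these compounds, compound 1 and compound 3 both give only a limit, so no step between them can be read. The compounds shown leave open what affinity any of them has, and whether fluoro in place of methyl changes it at all.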